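The compounds below may be only part of what the source reports. "The series", "measured", "known", "first", "only" and "open" are said of these compounds alone.

In a functional assay on MCF7 cells (Homo sapiens) for cytotoxicity, read by resazurin assay, with a stated time of 3 days (a higher number here means a weaker inhibitor, a lower number a stronger inhibitor), compound 1 (`CC(C)(CNC(=O)c1ccccc1)CC1=C(O)C(=O)c2ccccc2C1=O`) gives 37100 nM and lies within the scatter of compound 3 (`COc1cc(C(=O)NCC(C)(C)CC2=C(O)C(=O)c3ccccc3C2=O)c(O)c2ccccc12`) at 35600 nM here, while compound 2 (`CC(C)(CNC(=O)c1ccc2ccccc2c1O)CC1=C(O)C(=O)c2ccccc2C1=O`) shows a higher number at 79500 nM in this set. Compound 4 (`COc1ccc(OC)c(C(=O)NCC(C)(C)CC2=C(O)C(=O)c3ccccc3C2=O)c1`) carries 2,5-dimethoxyphenyl in place of phenyl on a carbonyl carbon. Within the data shown here, only one measured step bears on this change, methoxy in place of hydrogen on an aromatic carbon (a 2.2-fold lower number from compound 2 to compound 3 (0.35 log units; beyond the scatter)), which is modest and comes from a different aromatic group. In this assay a small move toward a lower number is therefore expected, probably none beyond the scatter. The expected change is a 1.2-fold lower number from compound 1 to compound 4 (0.09 log units; within the scatter) and stays within the scatter. Compound 4 is estimated at 30000 nM with an expected range from 14000 nM to 65000 nM in this measurement.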

Compound 4, half-maximal inhibitory concentration: 99400 nM
For compound 4 the middle estimate is 3.3-fold (0.52 log units) below the measured one, outside the stated range (above it).
By their numbers in this assay, from the lowest: compounds 3 and 1 (each within the scatter of the next); then compounds 2 and 4 (each within the scatter of the next).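

In this assay the exchange of phenyl for 2,5-dimethoxyphenyl on the carbonyl carbon gives a 2.7-fold higher number from compound 1 to compound 4 (0.43 log units; beyond the scatter) and so shows that this position responds to the change. Among these compounds, the direction is opposite to the one earlier methoxy step, a 2.2-fold lower number from compound 2 to compound 3 (0.35 log units; beyond the scatter) on a different aromatic group, so that step did not carry over here. Nothing measured here accounts for the difference.

From the compounds shown here alone, whether one methoxy alone gives this step remains open. So does the effect of an amine or a carboxylic acid on the phenyl ring.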